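The source may report more compounds than this note shows. Statements on the series, on what has been measured and on what is new or still open speak of the compounds shown alone.

compound 1 `C=CC(=O)Nc1ccc(Cl)c(S(=O)(=O)N(C)C)c1`: > 30000 nM (a limit, not a number)
compound 2 `C=CC(=O)Nc1nc(-c2ccccc2OC)cs1`: > 30000 nM (a limit, not a number)
compound 3 `C=CC(=O)N(CC(=O)OCC)c1nc(-c2ccccc2)cs1`: 19000 nM

Among the compounds with values here, in a functional assay on HT-29 cells (Homo sapiens) for antiproliferative activity, read by MTT assay, with a stated time of 72 h (a lower number here means a stronger inhibitor, a higher number a weaker inhibitor), compound 3 is the only one with an actual number (19000 nM). The other two entries are not numbers: the limit of > 30000 nM in this assay, at which 2 of the 3 values shown sit.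

Compound 4 `C=CC(=O)N(Cc1cccnc1)c1nc(-c2ccccc2)cs1` carries pyridin-3-yl in place of ethoxycarbonyl on a saturated chain carbon bound to an amide-type nitrogen. Within the data shown here, no measured pair shows what such a swap does. Among the measured compounds shown here, with compound 3 at 19000 nM as the only starting number, a small move towards a lower number is expected in this assay, possibly no larger than the usual scatter. The expected change is a 1.6-fold lower number from compound 3 to compound 4 (0.20 log units; within the scatter), an estimate only. Compound 4 is estimated at 12000 nM (expected range 3000 nM to 30000 nM).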

Compound 4, half-maximal inhibitory concentration: > 30000 nM
Compound 4: a limit, no number; the forecaster's own chance of this, stated with the estimate: 30%; at least 2.5-fold (0.39 log units) between middle value and limit.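

Within the data shown here, on the saturated chain carbon bound to an amide-type nitrogen, replacing (ethoxycarbonyl)methyl with (pyridin-3-yl)methyl gives the first step that can be read in this assay: an at least 1.5-fold higher number from compound 3 to compound 4 (0.19 log units; that floor lies within the scatter). Going by these compounds, this figure is only a floor, so how far apart the two compounds really stand remains unknown. Compound 4 ends at a limit rather than a number, and so the pyridine ring gives no measurable activity here, leaving compound 3 as the only compound with a number: the limit of > 30000 nM in this assay, at which 3 of the 4 values shown sit.

On these data alone, whether a carboxylic acid, an amine or a longer chain in this place would give a number remains open. So does the size of any change such groups would bring.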